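The source may report more compounds than this note shows. Statements on the series, on what has been measured and on what is new or still open speak of the compounds shown alone.

In a functional assay on HeLa cells (Homo sapiens) for cytotoxicity, read by MTT assay, with a stated time of 72 h, tested at 3 uM (a higher number here means more inhibition of growth at the concentration tested, a lower number less inhibition of growth), the measured compounds are:

compound 1, `N/C(=N\NC(=S)N1CCCCCC1)c1ccccn1`, giving 36.6%
compound 2, `N/C(=N\NC(=S)N1CCOCC1)c1ccccn1`, giving 40%
compound 3, `Cc1cccc(/C(N)=N/NC(=S)N2CCOCC2)n1`, giving 65.7%

Among the measured compounds shown here, compound 3 stands highest of the three, and the only step that differs in one place is a number 25.7 percentage points higher from compound 2 to compound 3 (beyond the scatter), a methyl in place of hydrogen on an aromatic carbon. For the measured compounds named here, compound 1 lies furthest from compound 3, but no single-place step links those two.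

Compound 4, `Cc1cccc(/C(N)=N/NC(=S)N2CCCC2)n1`, differs from compound 3 by pyrrolidin-1-yl in place of morpholin-4-yl on a thiocarbonyl carbon. Going by the values given here, no measured step changes this amine ring while keeping everything else fixed, so none bears on it directly. The nearest guide is the pair of compounds 1 and 2, which carry different amine rings on the thiocarbonyl carbon and whose values sit close to each other. On that basis a step of no size beyond the scatter is expected in this assay. Compound 4 is therefore estimated at 62%, within a range from 45% to 78%. The expected change is a number 3.7 percentage points lower from compound 3 to compound 4 (within the scatter).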

Compound 4, percent growth inhibition at one concentration: 56.8%
Compound 4: middle estimate off by 5.2 percentage points, on the high side; the measured number falls inside the stated range.
By their numbers in this assay, from the lowest: compounds 1 and 2 (each within the scatter of the next); then compounds 4 and 3 (each within the scatter of the next).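

In this assay, among the compounds shown here, pyrrolidin-1-yl in place of morpholin-4-yl on a thiocarbonyl carbon gives a number 8.9 percentage points lower from compound 3 to compound 4 (within the scatter), the first measured step that isolates the amine ring with the rest of the molecule held fixed. At this place, then, the morpholin-4-yl ring, with its oxygen and its hydrogen-bond acceptor, can give way to the smaller five-membered ring without a difference that can be told from the scatter in this one pair. No available measurement explains why the two rings read alike.

On these data alone, it remains open whether other groups on the thiocarbonyl carbon, such as piperazin-1-yl or an open-chain dimethylamino group, would read the same. Also open, as far as these compounds go, is whether a number 25.7 percentage points higher from compound 2 to compound 3 (beyond the scatter) would recur with pyrrolidin-1-yl on the thiocarbonyl carbon, or with ethyl in place of that methyl.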